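Notes on replacing 4-chlorophenyl in compound 2

The compounds below may be only part of what the source reports. "The series", "measured", "known", "first", "only" and "open" are said of these compounds alone.

Values in a functional assay on MDA-MB-231 cells (Homo sapiens) for antiproliferative activity, with a stated time of 4 days; a higher number here means a weaker inhibitor, a lower number a stronger inhibitor:
- compound 1 `COc1ccc(-c2[nH]c3ccc(C)cc3c2C=O)cc1`: 86 nM
- compound 2 `CCCCc1ccc2[nH]c(-c3ccc(OC)cc3)c(/C=N/NC(=O)c3ccc(Cl)cc3)c2c1`: 90 nM
- compound 3 `CCCCc1ccc2[nH]c(-c3ccc(C(F)(F)F)cc3)c(/C=N/NC(=O)c3ccc(Cl)cc3)c2c1`: 329 nM

Compound 2 cannot be separated from compound 1 on these numbers, while compound 3 reads higher. The change to compound 4 `CCCCc1ccc2[nH]c(-c3ccc(OC)cc3)c(/C=N/NC(=O)c3cccc(O)c3)c2c1` is 3-hydroxyphenyl in place of 4-chlorophenyl on a carbonyl carbon. Among the compounds with values here, no measured step covers this place. Within the data shown here, the one measured step, a 3.7-fold higher number from compound 2 to compound 3 (0.56 log units; beyond the scatter), puts trifluoromethyl in place of methoxy on an aromatic carbon, so it bears only indirectly: a single group change can pass the scatter modestly. A modest rise in this assay is expected, with the direction weakly supported. The step expected is a 1.6-fold higher number from compound 2 to compound 4 (0.19 log units; within the scatter) and it is only an estimate. For compound 4 the estimated value is 140 nM (expected range 45 nM to 450 nM).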

Compound 4, half-maximal inhibitory concentration: 30 nM
Estimate against measurement, compound 4: 4.7-fold (0.67 log units) above; measured number outside the range, below it.
By their numbers in this assay, from the lowest: compound 4; then compounds 1 and 2 (each within the scatter of the next); then compound 3.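

In this assay, the group on the carbonyl carbon is shown to matter: 3-hydroxyphenyl in place of 4-chlorophenyl gives a 3.0-fold lower number from compound 2 to compound 4 (0.48 log units; beyond the scatter). The only earlier step, trifluoromethyl in place of methoxy, raised the number, so this is the first change shown to lower it. Nothing measured here accounts for the step.

Both the substituent and its place on the ring differ in this change, and the compounds shown do not separate the two. On these data alone, how an amine or a carboxylic acid in place of the hydroxy group would read remains open.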